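Nitro in place of hydrogen: from compound 2 to compound 4

The source may hold more compounds than are shown below. What is called first, only, known or untested is meant among the compounds shown, and "the series" means these compounds.

Compound 1, `Cc1cc(CCc2cc(C)nn2-c2ccccc2)n(-c2ccccc2)n1`: 1.3
Compound 2, `Cc1cc(COc2cc(C)nn2-c2ccccc2)n(-c2ccccc2)n1`: 2.2
Compound 3, `Cc1cc(OCCOc2cc(C)nn2-c2ccccc2)n(-c2ccccc2)n1`: -1.6

All three were measured in a physicochemical assay for lipophilicity, at pH 7.4, tested at 10 mM; a higher number here means a more lipophilic compound, a lower number a more polar compound. Compound 2 stands highest of the three: in this assay compound 2 gives 2.2. Compound 1 gives 1.3, a lower number, and the gap lies beyond the usual scatter. Compound 3 gives -1.6, lower still, and far beyond the scatter.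

Compound 4, `Cc1cc(COc2cc(C)nn2-c2ccc([N+](=O)[O-])cc2)n(-c2ccccc2)n1`, has not yet been measured. It differs from compound 2 in one place: nitro in place of hydrogen on an aromatic carbon. Within the data shown here, no pair of measured compounds shows this kind of change, so there is no measured step to lean on. The expected step in this assay, a number 0.20 log units lower from compound 2 to compound 4 (within the scatter), is small, at most a slight move downward, and may well fall within the scatter. Compound 4 is therefore estimated at 2, with a range from 1.4 to 2.6.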

Compound 4, distribution coefficient: 3.7
For compound 4 the middle estimate is 1.70 log units below the measured one; measured number above the stated range.
By their numbers in this assay, from the lowest: compound 3; then compound 1; then compound 2; then compound 4.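

In this assay the change from phenyl to 4-nitrophenyl gives a number 1.50 log units higher from compound 2 to compound 4 (beyond the scatter) for one group added on an aromatic carbon. Among these compounds, this is the first step that can be read between two compounds differing in one place, and it shows that this carbon, para to a large group, is not a silent position: nitro in place of hydrogen moves the number well past the usual scatter, and upward. Nothing available explains the direction or the size of this step.

From the compounds shown here alone, whether a different group at this same carbon, such as an amine, a nitrile or a carboxylic acid, would move the number the same way remains open. So does whether nitro would give a similar step on the other phenyl ring, or on the cores of compound 1 and compound 3.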